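Methoxy for Methyl in Two Related Scaffolds

The source may report more compounds than this note shows. Statements on the series, on what has been measured and on what is new or still open speak of the compounds shown alone.

Compound 1 has the structure `Cc1ccc2c(c1)-c1cnc(n1C)OCCCCCCCCO2` and in a functional assay on LoVo cells (Homo sapiens) for inhibition, read by colorimetric assay and MTT assay, with a stated time of 72 h (on this read-out lower numbers stand for stronger inhibition and higher numbers for weaker inhibition), compound 1 gives 34000 nM. Compound 2, with the structure `COc1ccc2c(c1)-c1cnc(n1C)OCCCCCCCCO2`, carries one change, (methoxy in place of methyl on an aromatic carbon), and in this assay compound 2 gives 34000 nM. The resulting step is no change at the digits printed from compound 1 to compound 2 (within the scatter).

Compound 3, with the structure `C=CCCCCOc1ccc(C)cc1-c1cnc(OCCC=C)n1C`, has a core that differs from the core of compound 1 in a way that is not broken down here; in this assay compound 3 gives 41000 nM. Compound 4 has the structure `C=CCCCCOc1ccc(OC)cc1-c1cnc(OCCC=C)n1C` and is not yet measured. It differs from compound 3 by methoxy in place of methyl on an aromatic carbon. Among the measured compounds shown here, this is the same kind of change as the one from compound 1 to compound 2, but its surroundings differ: in compound 1 the ring is part of a fused or bridged system of three rings, meta to a fused ring and para to a fused ring, whereas in compound 3 the ring is meta to a large group and para to a (hex-5-en-1-yl)oxy group.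

The step expected for compound 4 is no change at the digits printed from compound 3 to compound 4 (within the scatter), a small one because the earlier step of no change at the digits printed from compound 1 to compound 2 (within the scatter) stayed within the scatter. Compound 4 is therefore estimated at 41000 nM, between 20000 nM and 85000 nM.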

Compound 4, half-maximal inhibitory concentration: 33000 nM
Estimate against measurement, compound 4: 1.2-fold (0.09 log units) above; the range from low to high includes it.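

In this assay, swapping methyl for methoxy on the aromatic carbon of the open-chain core gives a 1.2-fold lower number from compound 3 to compound 4 (0.09 log units; within the scatter), so this step, like the one on the core of compound 1, stays within the ordinary spread of repeat measurements. Side by side, the two steps agree, which means that in this small set the change carries from one core to the other without a visible difference: the same change on two cores in this assay, no change at the digits printed (within the scatter) from compound 1 to compound 2 and a 1.2-fold lower number (0.09 log units; within the scatter) from compound 3 to compound 4, 1.2-fold (0.09 log units) apart, within the scatter of two such steps. Among the compounds shown here, this agreement rests on only two pairs of compounds, and since neither step rises above the scatter, it shows that the swap left the number in place on both cores, not that the two cores would respond alike to a change with a larger effect, nor why the swap does so little.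

Going by these compounds, whether an amine or a carboxylic acid on the same aromatic carbon would move the number beyond the scatter on either core remains open. So does the effect of a longer chain in place of the (hex-5-en-1-yl)oxy group.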